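Putting Cyano in Place of Nitro in Compound 2

The source may hold more compounds than are shown below. What is called first, only, known or untested is meant among the compounds shown, and "the series" means these compounds.

Of the compounds shown here, two have numbers so far in a functional assay on the whole organism with Rattus norvegicus as the target, at a dose of 25 mg/kg by the intravenous route (a higher number here means that more compound is needed for the effect, a lower number that less compound is needed), and they do not sit close together. Compound 1 `O=C(Nc1cccc(-c2nn[nH]n2)c1)c1cccc(-c2nn[nH]n2)c1` gives 1.6 mg/kg and compound 2 `O=C(Nc1ccc(C(=O)O)c(C(=O)O)c1)c1ccc([N+](=O)[O-])cc1` gives 13.2 mg/kg on the same scale. Compound 2 thus holds the higher of the two numbers, meaning that more of it is needed for the effect, and its gap to compound 1 lies beyond the usual scatter.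

The next structure is compound 3 `N#Cc1ccc(C(=O)Nc2ccc(C(=O)O)c(C(=O)O)c2)cc1`, which differs from compound 2 in one place. The change cyano in place of nitro on an aromatic carbon puts cyano in place of nitro on an aromatic carbon, para to a large group. Within the data shown here, no measured pair shows what this swap does, and compound 1 and compound 2 differ in too many places to serve as a guide. The expectation therefore rests on compound 2 at 13.2 mg/kg as its starting point. In this assay no step beyond the scatter is expected in either direction. The estimated change a 1.1-fold lower number from compound 2 to compound 3 (0.04 log units; within the scatter) is accordingly small. For compound 3 the expected value is 12 mg/kg with an estimated range from 4.5 mg/kg to 32 mg/kg around it.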

Compound 3, dose for 50% inhibition: 10.1 mg/kg
Beside the measured number, compound 3's estimate is 1.2-fold (0.07 log units) above it; the measured number falls inside the stated range.
By their numbers in this assay, from the lowest: compound 1; then compounds 3 and 2 (each within the scatter of the next).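

Putting cyano in place of nitro on an aromatic carbon, para to a large group, gives a 1.3-fold lower number from compound 2 to compound 3 (0.12 log units; within the scatter) in this assay, so compound 2 and compound 3 cannot be told apart on this read-out. Among these compounds, this is the first direct reading at this position, and it shows that nitro is not required there for a number of this size: cyano, with fewer heavy atoms and fewer hydrogen-bond acceptors, reads the same. No measurement at hand explains why the two groups read alike.

Going by these compounds, it remains open whether other groups at this position, such as an amine, a carboxylic acid or a plain hydrogen, would also read the same, or whether some group there would move the number beyond the scatter. Compound 1, at 1.6 mg/kg, differs from compound 2 and compound 3 in too many places, so these compounds cannot show which of its structural features goes with its lower number.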